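A Methoxy-for-Chloro Swap on a Limit-Bound Anilide

The compounds below may be only part of what the source reports. "The series", "measured", "known", "first", "only" and "open" are said of these compounds alone.

Measured compounds in an in vitro functional assay on HEK293-A cells for antagonist activity at metabotropic glutamate receptor 5 (Rattus norvegicus), read by calcium flux; on this read-out lower numbers stand for stronger inhibition and higher numbers for weaker inhibition:
compound 1 `N#Cc1cc(F)cc(C(=O)Nc2cccc(C(F)(F)F)n2)c1` gives > 10000 nM
compound 2 `N#Cc1cc(F)cc(C(=O)Nc2ccccc2Cl)c1` gives > 30000 nM
compound 3 `Cc1ccc(NC(=O)c2cc(F)cc(C#N)c2)cc1` gives > 30000 nM

Each of these values is a limit of the assay and not a number. Compound 1 sits at the limit of > 10000 nM in this assay, at which 1 of the 3 values shown sits. Compound 2 sits at the limit of > 30000 nM in this assay, at which 2 of the 3 values shown sit. Compound 3 ends at the same limit as compound 2. So compound 2 stands where the assay returns no figure, and no measured step among these three can be sized.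

Compound 4 `COc1ccccc1NC(=O)c1cc(F)cc(C#N)c1` differs from compound 2 by methoxy in place of chloro on an aromatic carbon. Among the measured compounds shown here, with no measured step to lean on, the expected step is a number no higher from compound 2 to compound 4 (the limit leaves the size open), none beyond the scatter. Compound 4 is therefore expected at 30000 nM, between 5000 nM and 100000 nM, most likely again as a limit.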

Compound 4, half-maximal inhibitory concentration: > 30000 nM
Compound 4: no number, only a limit; the forecaster's own chance of this, stated with the estimate: 80%; the middle value sits exactly at the limit.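

Among the compounds shown here, compound 2 and compound 4 both end at the same limit of the assay, so no step between them can be read. The compounds shown leave open whether methoxy in place of chloro changes inhibition at all.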